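Thiazolyl attachment isomers in the bombesin receptor subtype-3 series

This account rests on a few compounds, and the source may have more. Where it says the series, first, only, none or still open, it means among the compounds named here.

Among the measured compounds shown here, compound 2 `CCC(C)(C)Cc1c[nH]c(CCc2ccc(-c3cnsc3)cc2)n1` stands lowest of the two numbers so far: in a functional assay on HEK293 cells for agonist activity at Bombesin receptor subtype-3 (Mus musculus), read by luminescence and calcium flux, with a stated time of 10 min (on this read-out lower numbers stand for an effect already at smaller amounts and higher numbers for an effect only at larger amounts of compound), compound 2 gives 6.9 nM. Its nearest neighbour, compound 1 `CCC(C)(C)Cc1c[nH]c(CCc2ccc(-c3ccncc3)cc2)n1`, gives 15 nM in this assay, and the step of a 2.2-fold lower number from compound 1 to compound 2 (0.34 log units; beyond the scatter) is the only measured one in the series. Compound 3 `CCC(C)(C)Cc1c[nH]c(CCc2ccc(-c3ccns3)cc2)n1` is not yet measured. It differs from compound 2 by 1,2-thiazol-5-yl in place of 1,2-thiazol-4-yl on an aromatic carbon. For the measured compounds named here, no measured step exchanges one thiazolyl attachment for the other; the step from compound 1 to compound 2 exchanges pyridin-4-yl for 1,2-thiazol-4-yl and bears only loosely on the present change. Since the two isomers carry the same atoms, joined differently, a step within the scatter or at most modest in either direction is expected, with no grounds to favour a direction. For compound 3 the expected value in this assay is therefore 8 nM, between 3 nM and 25 nM, which is expected to be a step of a 1.2-fold higher number from compound 2 to compound 3 (0.06 log units; within the scatter).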

Compound 3, half-maximal effective concentration: 3.1 nM
Beside the measured number, compound 3's estimate is 2.6-fold (0.41 log units) above it; the range from low to high includes it.
By their numbers in this assay, from the lowest: compound 3; then compound 2; then compound 1.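

In this assay, moving the attachment point within the ring is enough to shift the number at this place, on an aromatic carbon para to a large group: with the same atoms joined differently, the change gives a 2.2-fold lower number from compound 2 to compound 3 (0.35 log units; beyond the scatter), a step of about the same size as the one from pyridin-4-yl to 1,2-thiazol-4-yl. Replacing pyridin-4-yl with 1,2-thiazol-5-yl gives a 4.8-fold lower number from compound 1 to compound 3 (0.68 log units; beyond the scatter), which leaves compound 3 with the lowest number of the three. Nothing shown here accounts for the difference between the two attachment isomers.

Still open, going by these compounds, is how a 1,3-thiazol-5-yl, a 1,3-thiazol-2-yl or a carboxylic acid at this place would compare with 1,2-thiazol-5-yl. Also open, on these data alone, is whether the gap between the isomers persists with a longer chain on the shared core.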